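From Methanesulfonamido to Methyl: One Aromatic Substitution

A few compounds are considered here, and "the series" means these few. Any claim that something is new, unique, unknown or untested is made for them only; others in the source may bear on it.

Three compounds share one core. Compound 1, `NC(=O)Nc1sc(-c2ccccc2)cc1C(=O)NC1CCCCC1`, was tested in a functional assay on HT-29 cells (Homo sapiens) (on this read-out lower numbers stand for an effect already at smaller amounts and higher numbers for an effect only at larger amounts of compound), but for compound 1 the entry is "not determined" (no result reported). Compound 2, `CS(=O)(=O)Nc1ccc(-c2cc(C(=O)N[C@H]3CCCNC3)c(NC(N)=O)s2)cc1`, was tested in this assay as well, where compound 2 gives 2200 nM. Among the compounds with values here, that is the only number in hand, so compound 2 is the sole point of reference for anything that follows.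

Compound 3, `Cc1ccc(-c2cc(C(=O)N[C@H]3CCCNC3)c(NC(N)=O)s2)cc1`, differs from compound 2 in a single place: methyl in place of methanesulfonamido on an aromatic carbon. Within the data shown here, no pair of measured compounds here shows what such a swap does, so the direction and size of the step can only be guessed. Trading a methanesulfonamido group, with its one hydrogen-bond donor and two acceptors, for a bare methyl removes most of what that part of the molecule offers, and the expectation is a modest shift toward larger amounts in this assay, possibly no more than the usual scatter. The expected step is a 1.6-fold higher number from compound 2 to compound 3 (0.20 log units; within the scatter). Compound 3 is expected to give about 3500 nM, with a likely range from 900 nM to 14000 nM.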

Compound 3, half-maximal effective concentration: 70 nM
Compound 3: middle estimate off by 50-fold (1.70 log units), on the high side; measured number outside the range, below it.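

In this assay, the group on this aromatic carbon, para to a large group, has a strong bearing on the result: methyl in place of methanesulfonamido gives a 31-fold lower number from compound 2 to compound 3 (1.50 log units; beyond the scatter), a step well beyond the usual scatter. The earlier compounds shown here could not show this, since compound 2 alone carried a number and offered nothing to compare it with. This single pair also shows that the methanesulfonamido group, with its hydrogen-bond donor and acceptors, is not required at this position for an effect in this assay, as methyl carries neither, yet the information at hand offers no explanation for the size of the step.

Going by these compounds, one pair cannot separate what methyl adds from what the loss of methanesulfonamido removes, so it remains open whether the low number belongs to methyl specifically or would also appear with another small group. On these data alone, how an amine, a carboxylic acid, a methoxy group or a longer chain such as ethyl would read at this same aromatic carbon remains unknown, and whether the step would carry over to other compounds on the shared core is also unsettled.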